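A few compounds are considered here, and "the series" means these few. Any claim that something is new, unique, unknown or untested is made for them only; others in the source may bear on it.

Working notes on the series, step from compound 1 to compound 4.

Compound 1 `NC1CCC(CN2CCN(c3cc(=O)c4cc(C(F)(F)F)cc([N+](=O)[O-])c4s3)CC2)CC1` is the parent of this small set. Going by the values given here, in an ADME assay on cells (Hepatocyte, Homo sapiens) for metabolic stability, with a stated time of 30 min (on this read-out lower numbers stand for a less stable compound and higher numbers for a more stable compound), compound 1 gives 83.6%, which is the second highest of the three numbers measured so far. Compound 2 `CS(=O)(=O)NC1CCC(CN2CCN(c3cc(=O)c4cc(C(F)(F)F)cc([N+](=O)[O-])c4s3)CC2)CC1` carries a methylsulfonyl in place of hydrogen on the amine nitrogen; in this assay compound 2 gives 105%, and the step of a number 21.4 percentage points higher from compound 1 to compound 2 (beyond the scatter) is modest. Compound 3 `Cc1ccc(C(=O)OC2CCC(CN3CCN(c4cc(=O)c5cc(C(F)(F)F)cc([N+](=O)[O-])c5s4)CC3)CC2)cc1` carries ((4-methylphenyl)carbonyl)oxy in place of amino on the saturated ring carbon; in this assay compound 3 gives 9.7%, and the step of a number 73.9 percentage points lower from compound 1 to compound 3 (beyond the scatter) is large, as is a number 95.3 percentage points lower from compound 2 to compound 3 (beyond the scatter).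

Compound 4 `O=C(OC1CCC(CN2CCN(c3cc(=O)c4cc(C(F)(F)F)cc([N+](=O)[O-])c4s3)CC2)CC1)c1ccc(F)cc1` differs from compound 1 by ((4-fluorophenyl)carbonyl)oxy in place of amino on a saturated ring carbon. Among the compounds with values here, the step that bears directly on it is the one to compound 3, where the same kind of group entered at the same place and the number fell by a large amount, a number 73.9 percentage points lower from compound 1 to compound 3 (beyond the scatter). A step of similar size and the same downward direction is therefore expected for compound 4, a number 68.6 percentage points lower from compound 1 to compound 4 (beyond the scatter). Compound 4 is estimated at 15%, with a range from 3% to 40%.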

Compound 4, percent of the compound remaining: 3%
The estimate for compound 4 lay 12 percentage points above the measured number, and the stated range covers the measured number.
By their numbers in this assay, from the lowest: compounds 4 and 3 (each within the scatter of the next); then compound 1; then compound 2.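

In this assay, fluoro in place of methyl on an aromatic carbon gives a number 6.7 percentage points lower from compound 3 to compound 4 (within the scatter), so compounds 3 and 4 cannot be told apart and the low number is not confined to the 4-methylphenyl group. The fall seen with compound 3 recurs with a second aryl ester on the saturated ring carbon, with a number 80.6 percentage points lower from compound 1 to compound 4 (beyond the scatter), and the step from the methanesulfonamido compound is also large, with a number 102 percentage points lower from compound 2 to compound 4 (beyond the scatter). Nothing available gives a reason for the low numbers of these two esters.

The compounds shown leave open whether the low numbers follow the ester link or the aryl ring, a question that an amide carrying the same 4-fluorophenyl group on that ring carbon would address. They also leave open how a small acetyl ester would compare on this read-out.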